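Moving the fluorine on the ester of compound 3

The source may report more compounds than this note shows. Statements on the series, on what has been measured and on what is new or still open speak of the compounds shown alone.

Measured in a functional assay on V79-379A cells (Cricetulus griseus) for cytotoxicity, read by MTT assay, in the presence of a further agent that is not named here; on this read-out higher numbers stand for weaker inhibition and lower numbers for stronger inhibition:

Compound 1 `COC1=CC(=O)c2c(c(CO)cn2C)C1=O` gives 240000 nM
Compound 2 `COC1=CC(=O)c2c(c(COC(=O)c3ccccc3F)cn2C)C1=O` gives 40 nM
Compound 3 `COC1=CC(=O)c2c(c(COC(=O)c3ccccc3F)c(C)n2C)C1=O` gives 2000 nM

Among these three numbers, compound 3 sits in the middle at 2000 nM and is the second highest, with compound 2 lower and compound 1 higher. The next compound to be measured is compound 4 `COC1=CC(=O)c2c(c(COC(=O)c3ccc(F)cc3)c(C)n2C)C1=O`. It carries 4-fluorophenyl in place of 2-fluorophenyl on a carbonyl carbon and is otherwise unchanged.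

Among the compounds with values here, only one measured step links two compounds that differ in one place. This is a 50-fold higher number from compound 2 to compound 3 (1.70 log units; beyond the scatter), a large change beyond the scatter, made by methyl in place of hydrogen on an aromatic carbon. That step lies at a different place in the structure, so it gives neither a size nor a direction for moving the fluorine. Within the data shown here, no measured pair shows such a move, and compound 1 has no fluorophenyl group at all.

The expectation therefore stays anchored on compound 3 at 2000 nM with no direction favoured, and the range is kept wide. The estimated outcome is no change at the digits printed from compound 3 to compound 4 (within the scatter), with no shift beyond the scatter expected. In this assay the estimate for compound 4 is 2000 nM, with an expected range from 600 nM to 6500 nM.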

Compound 4, half-maximal inhibitory concentration: 300 nM
Beside the measured number, compound 4's estimate is 6.7-fold (0.82 log units) above it, outside the stated range (below it).
By their numbers in this assay, from the lowest: compound 2; then compound 4; then compound 3; then compound 1.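

In this assay, the ester on the methylated core proves sensitive to where the fluorine sits on its aromatic ring: putting 4-fluorophenyl in place of 2-fluorophenyl on the carbonyl carbon gives a 6.7-fold lower number from compound 3 to compound 4 (0.82 log units; beyond the scatter), a modest step but one beyond the scatter. Within the data shown here, the only step available before this, a 50-fold higher number from compound 2 to compound 3 (1.70 log units; beyond the scatter), lay at a different place in the structure, so this is the first sign that the fluorophenyl group itself can shift the number, even though the group that leaves and the group that enters have the same atoms, joined differently. Nothing available on these compounds accounts for the shift, so the result stands as an observation without an explanation.

From the compounds shown here alone, what the 4-fluorophenyl ester does on the core without the added methyl stays open, so it cannot be told whether the two changes act independently or whether the size of this step depends on the methyl. Also open, going by these compounds, is how far this position tolerates other groups on the carbonyl carbon, such as 4-chlorophenyl, unsubstituted phenyl or a chain carrying an amine.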